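Swapping Trifluoromethyl for Methyl: A Second Test

The compounds below may be only part of what the source reports. "The series", "measured", "known", "first", "only" and "open" are said of these compounds alone.

Of the compounds shown here, three have been measured in a functional assay on A549 cells (Homo sapiens) for inhibition, read by MTT assay, with a stated time of 72 h; on this read-out higher numbers stand for weaker inhibition and lower numbers for stronger inhibition. Compound 1 `CN(C(=O)NC(=O)c1ccc(Cl)cc1Cl)c1nc(C(F)(F)F)c(C(=O)N/N=C/c2ccc(C(F)(F)F)cc2)s1` gives 9.4 ug/mL. Compound 2 `CN(C(=O)NC(=O)c1c(F)cccc1F)c1nc(C(F)(F)F)c(C(=O)N/N=C/c2cccc(C(F)(F)F)c2)s1` gives 27.6 ug/mL, and compound 3 `Cc1nc(N(C)C(=O)NC(=O)c2c(F)cccc2F)sc1C(=O)N/N=C/c1cccc(C(F)(F)F)c1` gives 30.3 ug/mL. Compound 3 differs from compound 2 in one place, (methyl in place of trifluoromethyl on an aromatic carbon), and that step was a 1.1-fold higher number from compound 2 to compound 3 (0.04 log units; within the scatter). How the core of compound 1 differs from that of compound 2 is not broken down here. Compound 4 `Cc1nc(N(C)C(=O)NC(=O)c2ccc(Cl)cc2Cl)sc1C(=O)N/N=C/c1ccc(C(F)(F)F)cc1` carries the same kind of change relative to compound 1, (methyl in place of trifluoromethyl on an aromatic carbon), with the surroundings of the place described in the same words. Because compound 1 gives 9.4 ug/mL and the earlier step was a 1.1-fold higher number from compound 2 to compound 3 (0.04 log units; within the scatter), compound 4 is expected to land at about 10 ug/mL, a step of a 1.1-fold higher number from compound 1 to compound 4 (0.03 log units; within the scatter), most likely between 5 ug/mL and 20 ug/mL.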

Compound 4, half-maximal inhibitory concentration: 30.2 ug/mL
Beside the measured number, compound 4's estimate is 3.0-fold (0.48 log units) below it; the whole stated range lies below it.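

Putting methyl in place of trifluoromethyl on the core of compound 1 gave a 3.2-fold higher number from compound 1 to compound 4 (0.51 log units; beyond the scatter) in this assay, which means weaker inhibition. The same change therefore did not carry over with the same result from one core to the other: the same change on two cores in this assay, a 1.1-fold higher number (0.04 log units; within the scatter) from compound 2 to compound 3 and a 3.2-fold higher number (0.51 log units; beyond the scatter) from compound 1 to compound 4, 2.9-fold (0.47 log units) apart, beyond the scatter of two such steps The two pairs differ from each other in more than one place, so these steps show that a result on one core is no safe guide to the other, but not which difference between the cores matters.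

The compounds shown leave open how an ethyl group, a chlorine atom or an amine would behave at this place on the ring. They also leave open which of the two steps a further core would resemble.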